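The compounds below may be only part of what the source reports. "The series", "measured", "known", "first", "only" and "open" are said of these compounds alone.

Compound 1 `Cc1ccc(N2CCN(CC(=O)Nc3nc4c(s3)CCCC4)CC2)cc1`: in an assay on isolated protein for inhibition of long-chain fatty acid transport protein 1 (Mus musculus), read by scintillation counting, with a stated time of 20 min (on this read-out higher numbers stand for weaker inhibition and lower numbers for stronger inhibition), compound 1 gives > 10000 nM, a limit of the assay rather than a number.
Compound 2 `O=C(CN1CCN(c2nccs2)CC1)Nc1nc2c(s1)CCCC2`: in this assay compound 2 gives 7900 nM.

Within the data shown here, compound 2 holds the only number measured so far in this assay; the remaining value is a limit (the limit of > 10000 nM in this assay, at which 1 of the 2 values shown sits). Compound 3 `O=C(CN1CCN(c2cccnc2)CC1)Nc1nc2c(s1)CCCC2` carries pyridin-3-yl in place of 1,3-thiazol-2-yl on an amine nitrogen in a ring. Among the measured compounds shown here, the one measured step, an at least 1.2-fold lower number from compound 1 to compound 2 (0.10 log units; that floor lies within the scatter), also swapped the ring on that nitrogen and stayed within the scatter. Compound 3 is therefore expected to show no step beyond the scatter, a 1.1-fold higher number from compound 2 to compound 3 (0.06 log units; within the scatter), with a real chance that this assay again reports only a limit. The estimate for compound 3 is 9000 nM, between 3500 nM and 25000 nM.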

Compound 3, half-maximal inhibitory concentration: > 10000 nM
Compound 3 ended at the assay's limit; the forecaster's own chance of this, stated with the estimate: 45%; at least 1.1-fold (0.04 log units) between middle value and limit.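

In this assay, pyridin-3-yl in place of 1,3-thiazol-2-yl on this amine nitrogen gives an at least 1.2-fold higher number from compound 2 to compound 3 (0.10 log units; that floor lies within the scatter), so only the floor of this step is known and its true size could be larger. The step between compound 1 and compound 3 cannot be read, as both values are limits. Compound 2 remains the only compound with a measured number, and the limit now holds most of the values: the limit of > 10000 nM in this assay, at which 2 of the 3 values shown sit.

Still open, going by these compounds, is whether any group on this nitrogen gives a clear step to a lower number. A 1,3-oxazol-2-yl ring, a benzyl group or a simple acetyl group would each test this.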